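The source may report more compounds than this note shows. Statements on the series, on what has been measured and on what is new or still open speak of the compounds shown alone.

Measured so far in a physicochemical assay for solubility, with a stated time of 18 h, at pH 7.4; on this read-out higher numbers stand for higher solubility and lower numbers for lower solubility:
compound 1 `COc1ccc(F)cc1CNCCCNc1ccnc2cc(Cc3cc(C)cc(C)c3)ccc12` gives 4200 nM;
compound 2 `COc1cccc(CNCCCNc2ccnc3cc(Oc4ccc(Cl)cc4)ccc23)c1O` gives 14500 nM;
compound 3 `COc1cccc(CNCCCNc2ccnc3cc(Cc4ccccc4)ccc23)c1O` gives 4200 nM.

Compound 1 stands level with compound 3 at the digits shown, the two lowest of the three numbers, while compound 2 sits higher, a gap beyond the scatter. The unmeasured compound 4 `COc1ccc(F)cc1CNCCCNc1ccnc2cc(CC(C)C)ccc12` differs from compound 1 in one place: isopropyl in place of 3,5-dimethylphenyl on a saturated chain carbon bound to an aromatic carbon. Within the data shown here, no measured step matches this change. Among the measured compounds shown here, the only measured step, a 3.5-fold lower number from compound 2 to compound 3 (0.54 log units; beyond the scatter), alters the same region of the shared core but swaps different groups, so it only hints that such changes shift this assay modestly. Compound 4 is therefore expected to move little, perhaps slightly upward, a 1.7-fold higher number from compound 1 to compound 4 (0.22 log units; within the scatter), with an estimated value of 7000 nM in a range from 2500 nM to 20000 nM.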

Compound 4, solubility: 4200 nM
The estimate for compound 4 lay 1.7-fold (0.22 log units) above the measured number; low and high end bracket the measured number.
By their numbers in this assay, from the lowest: compounds 1, 3 and 4 (each within the scatter of the next); then compound 2.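

With isopropyl in place of 3,5-dimethylphenyl on a saturated chain carbon bound to an aromatic carbon, this assay shows no change at the digits printed from compound 1 to compound 4 (within the scatter) for this change. At this position, then, an aromatic ring of carbon can give way to a small group without a ring and leave the read-out level, which the earlier step, with its different groups, could not show. Nothing measured here explains this flat result. Still open, on these data alone, is whether an amine or a carboxylic acid at this place would shift the number, and whether a longer chain would keep it level.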